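The source may report more compounds than this note shows. Statements on the series, on what has been measured and on what is new or still open speak of the compounds shown alone.

Compound 1 `Cc1n[nH]c(C(=O)O)c1Cc1ccc(-c2ccc(OC(F)(F)F)cc2)cc1` was tested in an assay on isolated protein for inhibition of 2-Hydroxyacid oxidase 2 (Homo sapiens), tested at 10 uM (a lower number here means a weaker effect, a higher number a stronger effect of the compound at the concentration tested), where compound 1 gives 29%. Among the three numbers available this is the second highest. Compound 3 `Cc1n[nH]c(C(=O)O)c1Cc1ccccc1C(F)(F)F` comes nearest: in this assay compound 3 gives 38%, a number within the scatter of compound 1. Compound 2 `Cc1n[nH]c(C(=O)O)c1Cc1cccc(C(=O)O)c1` lies furthest away; in this assay compound 2 gives 0%, a number beyond the scatter below compound 1. Compound 4 `Cc1n[nH]c(C(=O)O)c1Cc1ccc(-c2ccc(F)cc2)cc1` has not yet been measured. It differs from compound 1 in one place: fluoro in place of trifluoromethoxy on an aromatic carbon. Within the data shown here, no measured pair shows this change, so no step size is known for it. The change is expected to stay within the scatter, leaning slightly downward, which amounts to an expected a number 7 percentage points lower from compound 1 to compound 4 (within the scatter). Compound 4 is therefore estimated at 22%, with a range from 5% to 40%.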

Compound 4, a percentage reported as inhibition, at one concentration (the size of the read-out at that concentration, not a potency): 25%
Compound 4: middle estimate off by 3 percentage points, on the low side; the range from low to high includes it.
By their numbers in this assay, from the lowest: compound 2; then compounds 4, 1 and 3 (each within the scatter of the next, the first and the last beyond it).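

The first step measured at this place, on an aromatic carbon para to a large group, is a number 4 percentage points lower from compound 1 to compound 4 (within the scatter) in this assay. In this pair, then, fluoro can stand in place of trifluoromethoxy without a step beyond the scatter, although this single pair cannot show a general rule. Nothing available bears on the reason for this result.

On these data alone, it remains open whether an amine or a carboxylic acid on this same carbon would shift the read-out beyond the scatter. As far as these compounds go, the effect of a plain hydrogen there also remains open.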